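From ethoxycarbonyl to carbamoyl: an estimate for compound 4

A few compounds are considered here, and "the series" means these few. Any claim that something is new, unique, unknown or untested is made for them only; others in the source may bear on it.

- compound 1 `CCCNCc1cc(-c2c(C(=O)NCC)noc2-c2cc(C(C)C)c(O)cc2O)on1`: 117 nM
- compound 2 `CCCN(CCC)Cc1cc(-c2c(C(=O)NCC)noc2-c2cc(C(C)C)c(O)cc2O)on1`: 183 nM
- compound 3 `CCNC(=O)c1noc(-c2cc(C(C)C)c(O)cc2O)c1-c1cc(C(=O)OCC)no1`: "not determined" (no result reported)

In a functional assay on HCT-116 cells (Homo sapiens) for inhibition (a lower number here means a stronger inhibitor, a higher number a weaker inhibitor), compound 3 has no number to stand on, its entry reading "not determined" (no result reported). Compound 4 `CCNC(=O)c1noc(-c2cc(C(C)C)c(O)cc2O)c1-c1cc(C(N)=O)no1` follows from compound 3 by one change, amino in place of ethoxy on a carbonyl carbon. This turns 3-(ethoxycarbonyl)-1,2-oxazol-5-yl into 3-carbamoyl-1,2-oxazol-5-yl.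

Going by the values given here, the only measured step is a 1.6-fold higher number from compound 1 to compound 2 (0.19 log units; within the scatter). That step is propyl in place of hydrogen on an amine nitrogen, so it does not bear directly on a change at a carbonyl carbon. With no starting value, no size or direction of step can be expected from compound 3 to compound 4. The estimate therefore rests on the two measured relatives, compound 1 at 117 nM and compound 2 at 183 nM, and its range is kept wide. Compound 4 is expected near 150 nM, with an estimated range from 40 nM to 600 nM.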

Compound 4, half-maximal inhibitory concentration: 79 nM
The estimate for compound 4 lay 1.9-fold (0.28 log units) above the measured number, within the range that was stated.
By their numbers in this assay, from the lowest: compounds 4, 1 and 2 (each within the scatter of the next, the first and the last beyond it).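

The step from compound 3 to compound 4 cannot be read, for compound 3 has no number in this assay. Going by these compounds alone, compound 4 instead gives the first value for a carbonyl group at this aromatic carbon, and its comparison is with the amine side chains: carbamoyl in place of (dipropylamino)methyl gives a 2.3-fold lower number from compound 2 to compound 4 (0.36 log units; beyond the scatter), while carbamoyl in place of (propylamino)methyl gives a 1.5-fold lower number from compound 1 to compound 4 (0.17 log units; within the scatter). Among these compounds, then, a side chain without an amine nitrogen still gives a number of this order.

Where the ethoxycarbonyl of compound 3 stands against the carbamoyl of compound 4 remains open. So does what a carboxylic acid or a methylamide would give on this carbonyl carbon.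

No measurement offered here accounts for these numbers.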